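Dropping One Methoxy from the Aryl Ring of Compound 1

This account rests on a few compounds, and the source may have more. Where it says the series, first, only, none or still open, it means among the compounds named here.

Compound 1 `COc1ccc(-c2cc(N)c(C(=O)c3cc(OC)c(OC)c(OC)c3)s2)cc1OC` is one of three close analogues that share a core and differ only in the aryl group attached to it. Within the data shown here, in a functional assay on L1210 cells (Mus musculus) for antiproliferative activity (on this read-out lower numbers stand for stronger inhibition and higher numbers for weaker inhibition), compound 1 gives 40 nM, which places it second highest of the three numbers known so far. Compound 2 `COc1cc(C(=O)c2sc(-c3ccc(I)cc3)cc2N)cc(OC)c1OC` gives 400 nM, a step of a 10-fold higher number from compound 1 to compound 2 (1.00 log units; beyond the scatter). Compound 3 `COc1cc(C(=O)c2sc(-c3cccc([N+](=O)[O-])c3)cc2N)cc(OC)c1OC` gives 11 nM, a step of a 3.6-fold lower number from compound 1 to compound 3 (0.56 log units; beyond the scatter); between the two of them lies a 36-fold lower number from compound 2 to compound 3 (1.56 log units; beyond the scatter).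

Compound 4 `COc1ccc(-c2cc(N)c(C(=O)c3cc(OC)c(OC)c(OC)c3)s2)cc1` differs from compound 1 in one place: hydrogen in place of methoxy on an aromatic carbon. Among the measured compounds shown here, no measured step removes a single methoxy from this aryl group; the two steps leading away from compound 1 each replace the whole 3,4-dimethoxyphenyl with a different aryl, and they bracket the outcome with a 10-fold higher number from compound 1 to compound 2 (1.00 log units; beyond the scatter) on one side and a 3.6-fold lower number from compound 1 to compound 3 (0.56 log units; beyond the scatter) on the other. The change to compound 4 is smaller than either of those, so a step smaller than both is expected in this assay, in either direction, and one that may well stay within the scatter. Compound 4 is therefore estimated at 30 nM, with a range from 8 nM to 120 nM. The expected step is a 1.3-fold lower number from compound 1 to compound 4 (0.12 log units; within the scatter).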

Compound 4, half-maximal inhibitory concentration: 45 nM
Estimate against measurement, compound 4: 1.5-fold (0.18 log units) below, and the stated range covers the measured number.
By their numbers in this assay, from the lowest: compound 3; then compounds 1 and 4 (each within the scatter of the next); then compound 2.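

In this assay, cutting 3,4-dimethoxyphenyl back to 4-methoxyphenyl gives a 1.1-fold higher number from compound 1 to compound 4 (0.05 log units; within the scatter) and so leaves the read-out unchanged within the scatter, which shows that this position, ortho to a methoxy group, accepts hydrogen in place of methoxy on the shared core. The remaining substituent tells a different story: an 8.9-fold lower number from compound 2 to compound 4 (0.95 log units; beyond the scatter) with methoxy in place of iodo, and a 4.1-fold higher number from compound 3 to compound 4 (0.61 log units; beyond the scatter) with 4-methoxyphenyl in place of 3-nitrophenyl, so compound 4 keeps the separation from compound 2 and compound 3 that compound 1 showed, and the wide spread among these aryl groups does not depend on the methoxy that was removed. Nothing in hand explains why this methoxy can be exchanged for hydrogen with no change beyond the scatter.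

What the compounds shown leave open is whether the position tolerates anything other than methoxy and hydrogen, such as a hydroxyl, an amine or a longer chain like ethoxy. They also leave open whether the remaining methoxy could itself give way to hydrogen, leaving a plain phenyl on the core.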